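Swapping the amide substituent for a hydroxycyclobutyl ring

The source may hold more compounds than are shown below. What is called first, only, known or untested is meant among the compounds shown, and "the series" means these compounds.

Compound 1 `CNC(=O)c1cc(C(=O)N[C@@H]2C[C@H]2CO)cc2c1O[C@H](CF)[C@H]2c1ccccc1` gives 1.65 mL/min in an ADME assay on cells (Hepatocyte, Rattus norvegicus, strain Wistar Han) for pharmacokinetics, read by LC-MS, tested at 0.5 uM; on this read-out lower numbers stand for slow clearance and higher numbers for fast clearance.
Compound 2 `CNC(=O)c1cc(C(=O)NCC[C@@H]2CNCCO2)cc2c1O[C@H](CF)[C@H]2c1ccccc1` gives 1.28 mL/min in this assay.
Compound 3 `CNC(=O)c1cc(C(=O)NCCC[C@H]2OC[C@H](N)CO2)cc2c1O[C@H](CF)[C@H]2c1ccccc1` gives 1.39 mL/min in this assay.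

All three numbers sit within the usual scatter of one another. Compound 3 lies nearest to compound 2 and furthest from compound 1, yet neither gap counts as a real difference.

Compound 4 `CNC(=O)c1cc(C(=O)N[C@H]2C[C@H](O)C2)cc2c1O[C@H](CF)[C@H]2c1ccccc1` differs from compound 3 in one place: a group of 5 heavy atoms (4 carbon, 1 oxygen; one four-membered non-aromatic ring of carbon only) in place of a group of 10 heavy atoms (7 carbon, 1 nitrogen, 2 oxygen; one six-membered non-aromatic ring with 2 hetero atoms), on an amide-type nitrogen. The measured steps that bear on this are the earlier swaps on the same amide-type nitrogen, a 1.3-fold lower number from compound 1 to compound 2 (0.11 log units; within the scatter) and a 1.2-fold lower number from compound 1 to compound 3 (0.07 log units; within the scatter), and the chain-end swap a 1.1-fold higher number from compound 2 to compound 3 (0.04 log units; within the scatter). None of them moved the number beyond the scatter, so the shared core appears to set the clearance here, and the group on the amide-type nitrogen matters little.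

Compound 4 is therefore expected to show a 1.1-fold higher number from compound 3 to compound 4 (0.03 log units; within the scatter), no step beyond the scatter. The estimate for compound 4 in this assay is 1.5 mL/min, with a likely range from 0.9 mL/min to 2.6 mL/min.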

Compound 4, intrinsic clearance in a liver preparation (reported as CLH), per the amount of preparation that the assay uses: 1.84 mL/min
Compound 4: middle estimate off by 1.2-fold (0.09 log units), on the low side; the measured number falls inside the stated range.
By their numbers in this assay, from the lowest: compounds 2, 3, 1 and 4 (each within the scatter of the next).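

In this assay, placing 3-hydroxycyclobutyl on the amide-type nitrogen gives a 1.3-fold higher number from compound 3 to compound 4 (0.12 log units; within the scatter) and a 1.4-fold higher number from compound 2 to compound 4 (0.16 log units; within the scatter) and also a 1.1-fold higher number from compound 1 to compound 4 (0.05 log units; within the scatter) in the comparison with the three-membered carbon ring of the same heavy-atom count. This position has now carried a four-membered carbon ring, a three-membered carbon ring and two different six-membered rings with 2 hetero atoms, and no step among these four compounds leaves the scatter. Nothing available here gives a reason for this flat result.

On these data alone, whether a carboxylic acid or a phenyl ring on this nitrogen would move the number beyond the scatter remains open. As far as these compounds go, all four compounds also share one core, so the effect of changes to that core on the read-out is still unknown.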